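Aryl swap on the ring nitrogen of the shared core

The source may report more compounds than this note shows. Statements on the series, on what has been measured and on what is new or still open speak of the compounds shown alone.

Of the compounds shown here, three of the shared core have so far been read in an assay on isolated protein for agonist activity at Bile acid receptor (Homo sapiens), read by AlphaScreen, with a stated time of 30 min; a lower number here means a smaller maximal response, a higher number a larger maximal response. Compound 1 `CCCc1ccccc1-n1nc(C)c2c1NC(=O)[C@H](C)S[C@@H]2c1ccc(Oc2ccccc2)cc1` gives 240% in this assay. Compound 2 `Cc1nn(-c2ccccc2C(F)(F)F)c2c1C(c1ccc(Oc3ccccc3)cc1)SC(C)C(=O)N2` gives 50%, and compound 3 `Cc1ccccc1-n1nc(C)c2c1NC(=O)[C@H](C)S[C@@H]2c1ccc(-c2ccsc2)cc1` gives 68%. Compound 1 therefore stands highest of the three numbers: the nearest number, that of compound 3, lies below it beyond the scatter, and the furthest, that of compound 2, lies lower still, also beyond the scatter. Among the measured compounds shown here, no two of the measured compounds differ in one place only, so no single step can be isolated; the values show only that the large maximal response is confined to compound 1.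

Compound 4 `Cc1cccc(-n2nc(C)c3c2NC(=O)[C@H](C)S[C@@H]3c2ccc(Oc3ccccc3)cc2)c1` has not yet been measured. It differs from compound 1 in one place: 3-methylphenyl in place of 2-propylphenyl on an aromatic nitrogen. Both measured compounds without the 2-propylphenyl group show small maximal responses, although each also carries further changes elsewhere. On that basis the step in this assay is expected to be downward and beyond the scatter, yet smaller than the gaps to compound 2 or compound 3, since the rest of the core is unchanged. Compound 4 is expected to give 110% in this assay, within 40% to 220%. The expected step is a number 130 percentage points lower from compound 1 to compound 4 (beyond the scatter).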

Compound 4, largest response reached (reported as efficacy), in percent of the reference or control that the assay uses: 22%
Compound 4: the middle estimate sits 88 percentage points above what was measured; the whole stated range lies above it.
By their numbers in this assay, from the lowest: compound 4; then compound 2; then compound 3; then compound 1.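

Among the compounds shown here, replacing 2-propylphenyl with 3-methylphenyl on the aromatic nitrogen, with the rest of the shared core unchanged, gives in this assay a number 218 percentage points lower from compound 1 to compound 4 (beyond the scatter) as the first step that can be assigned to a single place. The earlier compounds shown here carried further changes elsewhere, whereas this pair ties the high maximal response of compound 1 to the group at this one position: the phenoxyphenyl group, retained in compound 4, does not sustain that response without 2-propylphenyl on the nitrogen. The measurements shown offer no explanation for the size of this step.

The step changes the chain and its place on the phenyl ring together, so the contributions of shortening propyl to methyl and of moving the substituent cannot be separated here; 3-propylphenyl and 2-ethylphenyl on the same nitrogen would address these two parts. Also open, from the compounds shown here alone, is how the maximal response behaves with a longer chain, such as 2-butylphenyl, or with an amine or a carboxylic acid at the end of the propyl chain.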